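Two Assay Limits and an Untested Chloro-Methyl Analogue

A few compounds are considered here, and "the series" means these few. Any claim that something is new, unique, unknown or untested is made for them only; others in the source may bear on it.

compound 1 `Cc1cccc(-n2nncc2CN2C(=O)C3(C(C#N)=C(N)Oc4c3c3nc5ccccc5nc3c3ccccc43)c3ccccc32)c1`: > 50000 nM
compound 2 `COc1ccc(-n2nncc2CN2C(=O)C3(C(C#N)=C(N)Oc4c(N)cc5nc6ccccc6nc5c43)c3ccccc32)cc1`: > 50000 nM

In a functional assay on HepG2 cells (Homo sapiens) for antiproliferative activity, read by MTT assay, with a stated time of 48 h (a lower number here means a stronger inhibitor, a higher number a weaker inhibitor), compound 1 `Cc1cccc(-n2nncc2CN2C(=O)C3(C(C#N)=C(N)Oc4c3c3nc5ccccc5nc3c3ccccc43)c3ccccc32)c1` gives > 50000 nM, which is a limit of the assay and not a number. Compound 2 `COc1ccc(-n2nncc2CN2C(=O)C3(C(C#N)=C(N)Oc4c(N)cc5nc6ccccc6nc5c43)c3ccccc32)cc1` gives > 50000 nM in this assay, again a limit rather than a measured number. For the measured compounds named here, compound 2 therefore stands where the only other value shown also stands: the limit of > 50000 nM in this assay, at which 2 of the 2 values shown sit. Compound 3 `Cc1ccc(-n2nncc2CN2C(=O)C3(C(C#N)=C(N)Oc4c(N)cc5nc6ccccc6nc5c43)c3ccccc32)cc1Cl` has not yet been measured in this assay; it differs from compound 2 by 3-chloro-4-methylphenyl in place of 4-methoxyphenyl on an aromatic nitrogen. Going by the values given here, no step between measured compounds exists here, so nothing shows how a change on this aromatic nitrogen moves the read-out. Because both known values sit at the limit of > 50000 nM in this assay, at which 2 of the 2 values shown sit, compound 3 is expected to stay beyond the limit as well. The expected step is a step that the limit leaves unreadable from compound 2 to compound 3. Compound 3 is estimated at about 70000 nM, with a range from 20000 nM to 250000 nM, and most likely the assay will again report only a limit.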

Compound 3, half-maximal inhibitory concentration: > 50000 nM
Compound 3: no number, only a limit; the forecaster's own chance of this, stated with the estimate: 80%; the middle value lies beyond the limit too.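

In this assay, for the compounds shown here, compound 3 gives > 50000 nM, a limit of the assay and not a number, so no step from compound 2 to compound 3 can be read. The values shown agree: the limit of > 50000 nM in this assay, at which 3 of the 3 values shown sit. The compounds shown leave open whether any change on the aromatic nitrogen would move the read-out to a readable number.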